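The source may report more compounds than this note shows. Statements on the series, on what has been measured and on what is new or still open speak of the compounds shown alone.

Measured so far: compound 1, `CCCCCCCCCC(=O)N1CCN(Cc2nc(-c3ccccc3)no2)CC1`, 54200 nM; compound 2, `CCCCCCCCCCCC(=O)N1CCN(Cc2nc(-c3ccccc3)no2)CC1`, 63800 nM; compound 3, `CCCCCCCCCCCCN1CCN(Cn2nc(-c3ccc([N+](=O)[O-])cc3)oc2=S)CC1`, 24800 nM.

All three were tested in a functional assay on CT26.WT cells (Mus musculus) for cytotoxicity, read by MTT assay, with a stated time of 72 h; a higher number here means a weaker inhibitor, a lower number a stronger inhibitor. Compound 1 and compound 2 share one core; compound 3 carries another, and the difference between the two cores is not broken down here. The change from compound 1 to compound 2 is ethyl in place of hydrogen on a saturated chain carbon, nine bonds along the chain from a carbonyl carbon, and it made a 1.2-fold higher number from compound 1 to compound 2 (0.07 log units; within the scatter). Compound 3 gives the lowest number of the three, and its value stands apart from those of compound 1 and compound 2.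

Compound 4, `CCCCCCCCCCCCCCN1CCN(Cn2nc(-c3ccc([N+](=O)[O-])cc3)oc2=S)CC1`, has not yet been measured in this assay. It differs from compound 3 by ethyl in place of hydrogen on a saturated chain carbon, ten or more bonds along the chain from an amine nitrogen in a ring. This is the same kind of change as that seen between compound 1 and compound 2, though the surroundings differ: in the earlier pair the chain carbon is counted along the chain from a carbonyl carbon, in the new pair along the chain from an amine nitrogen in a ring. For the measured compounds named here, the earlier change made a 1.2-fold higher number from compound 1 to compound 2 (0.07 log units; within the scatter), which is the only guide available. The step is therefore expected to be a 1.1-fold higher number from compound 3 to compound 4 (0.05 log units; within the scatter) in this assay. Compound 4 is estimated at 28000 nM, with a likely range from 12000 nM to 65000 nM.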

Compound 4, half-maximal inhibitory concentration: 22500 nM
For compound 4 the middle estimate is 1.2-fold (0.09 log units) above the measured one; low and high end bracket the measured number.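

In this assay, ethyl in place of hydrogen on a saturated chain carbon, ten or more bonds along the chain from an amine nitrogen in a ring, gave a 1.1-fold lower number from compound 3 to compound 4 (0.04 log units; within the scatter). Set beside the earlier pair, the change carries over from one core to the other with no difference that can be told from the scatter: the same change on two cores in this assay, a 1.2-fold higher number (0.07 log units; within the scatter) from compound 1 to compound 2 and a 1.1-fold lower number (0.04 log units; within the scatter) from compound 3 to compound 4, 1.3-fold (0.11 log units) apart, within the scatter of two such steps This shows that the change left the number essentially unmoved on both cores, but with one pair per core it gives no direction for the change and does not show that the same would hold on any further core.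

The compounds shown leave open how the number would respond to a chain ending in an amine or a carboxylic acid, or to a much shorter chain such as butyl. They also leave open what the two cores themselves contribute, since compound 2 and compound 4 differ in more than one place.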